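The compounds below may be only part of what the source reports. "The series", "measured", "known", "first", "only" and "open" are said of these compounds alone.

Measured so far in a functional assay on CHO-K1 cells for antagonist activity at transient receptor potential cation channel subfamily V member 1 (Homo sapiens), read by FLIPR; on this read-out lower numbers stand for stronger inhibition and higher numbers for weaker inhibition:
compound 1 `Cc1ccc(Nc2nc(C(F)(F)F)ccc2CNC(=O)C(C)c2ccc(NS(C)(=O)=O)c(F)c2)cc1C`: 1160 nM
compound 2 `CCCCN(C)c1nc(C(F)(F)F)ccc1CNC(=O)C(C)c1ccc(NS(C)(=O)=O)c(F)c1`: 21.3 nM

Compound 2 stands lowest of the two numbers; the nearest is compound 1, reached by a 54-fold lower number from compound 1 to compound 2 (1.74 log units; beyond the scatter) in the reverse direction. Compound 3 `CC(C(=O)NCc1ccc(C(F)(F)F)nc1N1CC=CCC1)c1ccc(NS(C)(=O)=O)c(F)c1` differs from compound 2 by a group of 6 heavy atoms (5 carbon, 1 nitrogen; one six-membered non-aromatic ring with 1 hetero atom) in place of a group of 6 heavy atoms (5 carbon, 1 nitrogen; no ring), on an aromatic carbon. Within the data shown here, the single measured step, from (3,4-dimethylphenyl)amino to butyl(methyl)amino, was large, but compound 3 keeps a nitrogen-linked non-aromatic group of the same size, so in this assay no step beyond the scatter is expected, a 1.2-fold higher number from compound 2 to compound 3 (0.07 log units; within the scatter). Compound 3 is therefore estimated at 25 nM, between 8 nM and 80 nM.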

Compound 3, half-maximal inhibitory concentration: 12.1 nM
Beside the measured number, compound 3's estimate is 2.1-fold (0.32 log units) above it; the measured number falls inside the stated range.
By their numbers in this assay, from the lowest: compounds 3 and 2 (each within the scatter of the next); then compound 1.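

In this assay, a six-membered non-aromatic ring with 1 hetero atom in place of butyl(methyl)amino on this aromatic carbon stays within the scatter (a 1.8-fold lower number from compound 2 to compound 3 (0.25 log units; within the scatter)), so the open chain and this ring read alike here. The large step away from (3,4-dimethylphenyl)amino recurs with this second non-aromatic group (a 96-fold lower number from compound 1 to compound 3 (1.98 log units; beyond the scatter)), so it is not peculiar to butyl(methyl)amino. Nothing available gives a reason for either step. On these data alone, whether a piperidine ring without the double bond, a morpholine ring or the smaller dimethylamino group would read the same remains open.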